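The compounds below may be only part of what the source reports. "The series", "measured", "known", "first", "only" and "open" are said of these compounds alone.

Two compounds of the series carry numbers in an in vitro assay on HEK385-7 cells for displacement of a labelled ligand from prostaglandin D2 receptor 2 (Homo sapiens); on this read-out lower numbers stand for stronger inhibition and higher numbers for weaker inhibition. Compound 1 `O=C(O)Cc1sc(CS(=O)(=O)c2ccc(Cl)cc2)nc1-c1ccc(Cl)cc1` gives 1500 nM in this assay. Compound 2 `O=C(O)Cc1sc(C(c2ccc(F)cc2)c2ccc(F)cc2)nc1-c1cc(F)cc(F)c1` gives 35 nM in this assay. For the measured compounds named here, compound 2 thus stands lowest of the two, and compound 1 sits beyond the scatter above it, so the gap between them is real; with only two compounds, no single-change step within the measured set is available for comparison.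

Compound 3 `O=C(O)Cc1sc(C(c2ccc(F)cc2)c2ccc(F)cc2)nc1-c1ccnc(N2CCC2)c1` carries the change (2-(azetidin-1-yl)pyridin-4-yl in place of 3,5-difluorophenyl on an aromatic carbon), the rest of compound 2 being kept. Nothing measured in the series speaks to this particular swap on the five-membered aromatic ring with 1 nitrogen and 1 sulfur. The step is expected to be modest, near or within the scatter, with a slight lean toward a higher number: a 1.7-fold higher number from compound 2 to compound 3 (0.23 log units; within the scatter). Compound 3 is therefore estimated at 60 nM in this assay, within a range from 15 nM to 250 nM.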

Compound 3, half-maximal inhibitory concentration: 660 nM
Beside the measured number, compound 3's estimate is 11-fold (1.04 log units) below it, and the stated range ends below it.
By their numbers in this assay, from the lowest: compound 2; then compound 3; then compound 1.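

In this assay the aromatic carbon next to the ring nitrogen proves sensitive to its substituent: 2-(azetidin-1-yl)pyridin-4-yl in place of 3,5-difluorophenyl gives a 19-fold higher number from compound 2 to compound 3 (1.28 log units; beyond the scatter) and the step is large, beyond the scatter. For the compounds shown here, this is the first single-change step, and it shows that this position does not freely accept any six-membered aromatic ring. The entering group differs from the leaving one in several counted features at once, a ring nitrogen, a four-membered ring and two hydrogen-bond acceptors, and no measurement at hand accounts for the step.

From the compounds shown here alone, whether the pyridine nitrogen or the azetidine carries the change remains open. An unsubstituted pyridin-4-yl, or a 2-methoxypyridin-4-yl or 3-(azetidin-1-yl)phenyl group at this position, would separate the two.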